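Fluorine on an Aromatic Ring: Does Cell Tolerance Shift?

This account rests on a few compounds, and the source may have more. Where it says the series, first, only, none or still open, it means among the compounds named here.

Compound 1, `COc1c(N2CCN(CN3C(=O)C(=O)c4ccccc43)CC2)c(F)cc2c(=O)c(C(=O)O)cn(C3CC3)c12`, gives 70800 nM.
Compound 2, `COc1c(N2CCN(CN3C(=O)C(=O)c4cc(F)ccc43)CC2)c(F)cc2c(=O)c(C(=O)O)cn(C3CC3)c12`, gives 70600 nM.
Compound 3, `CO/N=C1\C(=O)N(CN2CCN(c3c(F)cc4c(=O)c(C(=O)O)cn(C5CC5)c4c3OC)CC2)c2ccccc21`, gives 76500 nM.

All three numbers come from an ADME assay on Vero cells (Chlorocebus sabaeus) for cytotoxicity, read by MTT assay, with a stated time of 72 h; a higher number here means that more compound is tolerated, a lower number that less compound is tolerated. Compound 1 and compound 2 share a core and differ in one place: fluoro in place of hydrogen on an aromatic carbon. The step of a 1.0-fold lower number from compound 1 to compound 2 (0.00 log units; within the scatter) shows that adding this fluorine left the number where it was.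

Compound 3 carries a different core; the difference between the core of compound 3 and the core of compound 1 is not broken down here. In this assay compound 3 sits within the scatter of both compound 1 and compound 2, so the three measured compounds cannot be told apart on tolerance.

Compound 4, `CO/N=C1\C(=O)N(CN2CCN(c3c(F)cc4c(=O)c(C(=O)O)cn(C5CC5)c4c3OC)CC2)c2ccc(F)cc21`, has not yet been measured. It differs from compound 3 in exactly the way compound 2 differs from compound 1: fluoro in place of hydrogen on an aromatic carbon. The place is the same in both pairs, so this is the same change, made a second time on a different core.

For the measured compounds named here, the expectation for compound 4 rests on the one earlier instance of this change, a 1.0-fold lower number from compound 1 to compound 2 (0.00 log units; within the scatter), which was flat. The step from compound 3 to compound 4 is therefore expected to be a 1.0-fold lower number from compound 3 to compound 4 (0.01 log units; within the scatter). Compound 4 is estimated at 75000 nM, with a range from 40000 nM to 140000 nM in this assay, pending the measurement.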

Compound 4, half-maximal cytotoxic concentration: 46800 nM
Beside the measured number, compound 4's estimate is 1.6-fold (0.20 log units) above it; the range from low to high includes it.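

On the core of compound 3, fluoro in place of hydrogen on an aromatic carbon gives a 1.6-fold lower number from compound 3 to compound 4 (0.21 log units; within the scatter) in this assay, so this step cannot be told apart from the ordinary spread of repeated measurements. This does not establish that the fluorine has no effect on every core in this series, since two pairs are a small sample and a result within the scatter can neither confirm nor rule out a small real effect. What the two pairs do show is that the change reads alike on the two cores, with no difference between them that stands clear of the scatter: the same change on two cores in this assay, a 1.0-fold lower number (0.00 log units; within the scatter) from compound 1 to compound 2 and a 1.6-fold lower number (0.21 log units; within the scatter) from compound 3 to compound 4, 1.6-fold (0.21 log units) apart, within the scatter of two such steps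

The compounds shown carry only hydrogen or fluoro at this place, so it remains open whether a chloro group, a nitrile or an amine there would also leave the number within the scatter on either core. As far as these compounds go, it also remains open whether fluoro at another carbon of the same six-membered aromatic ring, or on a third core, would behave as it does in these two pairs.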